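Swapping the ring on sulfur in a small series

This account rests on a few compounds, and the source may have more. Where it says the series, first, only, none or still open, it means among the compounds named here.

Of the compounds shown here, three on one shared core have been measured so far. In a functional assay on PC-3 cells (Homo sapiens) for inhibition, read by MTT assay, with a stated time of 72 h (a lower number here means a stronger inhibitor, a higher number a weaker inhibitor), compound 1 `CCN1CCN(c2cc(C(F)(F)F)nc(SCc3ccc(C(F)(F)F)cc3)n2)CC1` gives 27200 nM while compound 2 `Cc1csc(Sc2cc(C(F)(F)F)nc(SCc3ccc(C(F)(F)F)cc3)n2)n1` gives 12000 nM and compound 3 `FC(F)(F)c1ccc(CSc2nc(Sc3nncs3)cc(C(F)(F)F)n2)cc1` gives 7880 nM under the same conditions. Compound 3 cannot be told apart from compound 2, since the two lie within the usual scatter, and both stand lower than compound 1.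

Compound 4 `FC(F)(F)c1ccc(CSc2nc(Sc3ncc(-c4ccncc4)s3)cc(C(F)(F)F)n2)cc1` differs from compound 3 in one place, with 5-(pyridin-4-yl)-1,3-thiazol-2-yl in place of 1,3,4-thiadiazol-2-yl on a sulfur and so gains a six-membered aromatic ring.

Within the data shown here, the closest precedent is another exchange of one ring for another on that sulfur, a 1.5-fold lower number from compound 2 to compound 3 (0.18 log units; within the scatter) and it stays within the scatter. Replacing 4-ethylpiperazin-1-yl gave larger steps, a 2.3-fold lower number from compound 1 to compound 2 (0.36 log units; beyond the scatter) and a 3.5-fold lower number from compound 1 to compound 3 (0.54 log units; beyond the scatter) and both are modest. Among the measured compounds shown here, no measured compound carries a pyridin-4-yl group, and the data give no direction for it. No step beyond the scatter is therefore expected in this assay from this change. The expected step is a 1.3-fold lower number from compound 3 to compound 4 (0.12 log units; within the scatter) as an estimate only. For compound 4 the expected value is 6000 nM with an estimated range from 2000 nM to 20000 nM at this stage.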

Compound 4, half-maximal inhibitory concentration: 7350 nM
Compound 4: middle estimate off by 1.2-fold (0.09 log units), on the low side; the range from low to high includes it.
By their numbers in this assay, from the lowest: compounds 4, 3 and 2 (each within the scatter of the next); then compound 1.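

In this assay, the sulfur on the shared core carries the 5-(pyridin-4-yl)-1,3-thiazol-2-yl group, which brings a second aromatic ring, yet the result is a 1.1-fold lower number from compound 3 to compound 4 (0.03 log units; within the scatter), and the comparison with the smaller 4-methyl-1,3-thiazol-2-yl group gives a 1.6-fold lower number from compound 2 to compound 4 (0.21 log units; within the scatter). The earlier compounds shown here had only single rings on this sulfur, so the new finding is that a two-ring group with many more heavy atoms can sit here with no change that can be told from the scatter, and that compounds 2, 3 and 4 form one group of indistinguishable numbers. No measurement available here accounts for this insensitivity to the size of the group.

As far as these compounds go, what the pyridin-4-yl ring itself contributes remains open, since a plain phenyl ring in its place would be needed to separate the effect of its ring nitrogen from that of the added ring. From the compounds shown here alone, it is also open whether this tolerance extends to a group of another kind on the same sulfur, such as a carboxylic acid or a primary amine carried on a short chain.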